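A 3-methoxyphenyl group replaces 4-bromophenyl

The compounds below may be only part of what the source reports. "The series", "measured", "known", "first", "only" and "open" are said of these compounds alone.

- compound 1 (`COc1ccc(Nc2nc(N)c(C(=O)c3ccc(Br)cc3)s2)cc1`) gives 100 nM
- compound 2 (`COc1ccc(Nc2nc(N)c(C(=O)c3ccc([N+](=O)[O-])cc3)s2)cc1`) gives 310 nM
- compound 3 (`COc1ccc(Nc2nc(N)c(C(=O)c3cccc(OC)c3)s2)cc1`) has not yet been measured

In a functional assay on FM3A cells (Mus musculus) for antiproliferative activity, read by cell counting, with a stated time of 2 days (on this read-out lower numbers stand for stronger inhibition and higher numbers for weaker inhibition), compound 1 holds the lower of the two numbers, at 100 nM so far. Compound 3 carries 3-methoxyphenyl in place of 4-bromophenyl on a carbonyl carbon, and 3-methoxyphenyl in place of 4-bromophenyl on a carbonyl carbon counts that change. Within the data shown here, only one measured step also removes the bromo: nitro in its place gave a 3.1-fold higher number from compound 1 to compound 2 (0.49 log units; beyond the scatter) as a modest rise. On that single step, a similarly modest move toward a higher number is expected in this assay for compound 3. The estimate amounts to an expected 2.8-fold higher number from compound 1 to compound 3 (0.45 log units; beyond the scatter) overall. For compound 3 the estimated value is 280 nM, within an expected range of 90 nM to 900 nM here.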

Compound 3, half-maximal inhibitory concentration: 50 nM
For compound 3 the middle estimate is 5.6-fold (0.75 log units) above the measured one; measured number below the stated range.
By their numbers in this assay, from the lowest: compounds 3 and 1 (each within the scatter of the next); then compound 2.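

In this assay, 3-methoxyphenyl in place of 4-bromophenyl on a carbonyl carbon gives a 2.0-fold lower number from compound 1 to compound 3 (0.30 log units; within the scatter) and so keeps the read-out level with that of compound 1. Losing the bromo therefore does not by itself bring the rise seen with nitro, which gave a 3.1-fold higher number from compound 1 to compound 2 (0.49 log units; beyond the scatter) and stands as a feature of that replacement alone.

As far as these compounds go, whether an amine or a carboxylic acid in place of the methoxy would stay level with these two compounds remains open. Nothing measured here gives a reason for either step.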